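A few compounds are considered here, and "the series" means these few. Any claim that something is new, unique, unknown or untested is made for them only; others in the source may bear on it.

Measured compounds in a physicochemical assay for solubility, read by HPLC, at pH 6.8; on this read-out higher numbers stand for higher solubility and lower numbers for lower solubility:
- compound 1 `CC(C)(C)c1cc(NC(=O)[C@@H]2CCCCN2Cc2ccc(Cl)cc2)no1` gives < 0.1 ug/mL, which is a limit of the assay, not a number.
- compound 2 `CC(C)(C)c1cc(NC(=O)[C@@H]2CCCCN2C(=O)C2CCOCC2)no1` gives 48 ug/mL.

Within the data shown here, compound 2 therefore holds the only number in this assay; the one other value is a limit. Among the measured compounds shown here, the single measured step, an at least 480-fold higher number from compound 1 to compound 2 (2.68 log units; beyond the scatter), is large and runs toward higher solubility; its starting point sits at the limit (the limit of < 0.1 ug/mL in this assay, at which 1 of the 2 values shown sits), so its true size is open-ended.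

Compound 3 `CC(=O)N1CCN(C(=O)N2CCCC[C@H]2C(=O)Nc2cc(C(C)(C)C)on2)CC1` differs from compound 2 by 4-acetylpiperazin-1-yl in place of oxan-4-yl on a carbonyl carbon. For the measured compounds named here, no measured step covers this exchange: the one step measured swaps a 4-chlorobenzyl on the ring amine for an (oxan-4-yl)carbonyl, whereas here one carbonyl-linked group gives way to another, both without net charge, each counted with one hydrogen-bond acceptor and no donor. On that basis the exchange is expected to move the number little, if at all, beyond the scatter.

Compound 3 is accordingly expected to give 60 ug/mL, within 20 ug/mL to 180 ug/mL. The step this implies, a 1.3-fold higher number from compound 2 to compound 3 (0.10 log units; within the scatter), is an estimate only.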

Compound 3, solubility: 62 ug/mL
The estimate for compound 3 lay 1.0-fold (0.01 log units) below the measured number; the range from low to high includes it.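

In this assay, 4-acetylpiperazin-1-yl in place of oxan-4-yl on a carbonyl carbon gives a 1.3-fold higher number from compound 2 to compound 3 (0.11 log units; within the scatter), so the two groups cannot be told apart on this read-out. The earlier pair compared only a 4-chlorobenzyl with an (oxan-4-yl)carbonyl on the amine nitrogen in the ring; this pair keeps the carbonyl and shows that the group on it can be exchanged for one with more heavy atoms, a second ring nitrogen and an added acetyl without a step beyond the scatter, with both groups counted alike for hydrogen-bond donors and acceptors and both without net charge. The data shown offer no measured property that bears on this result.

Open, from the compounds shown here alone, is whether the read-out stays at this level with an amine or a carboxylic acid in the group on the carbonyl carbon, as both groups compared here carry no net charge. Also open, going by these compounds, is whether an oxan-4-ylmethyl on the amine nitrogen in the ring would read nearer to compound 1 or to compound 2, which would separate the carbonyl link from the ring it carries.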